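Urea series: pyridinyl to triazolyl swap on the benzyl arm

The source may report more compounds than this note shows. Statements on the series, on what has been measured and on what is new or still open speak of the compounds shown alone.

Compound 1 `CSc1cc(C)nc(SC)c1NC(=O)N(Cc1cccc(-c2cnn(C)c2)c1)C1CCCCCC1` gives only a limit of the assay in a functional assay on a cell-free system (plasma) with sterol O-acyltransferase, Soat (Rattus norvegicus) as the target (a higher number here means that more compound is needed for the effect, a lower number that less compound is needed), > 0.1 mg/kg. Compound 2 `O=C(Nc1c(F)cc(F)cc1F)N(Cc1ccc(-c2ccccn2)cc1)C1CCCCCC1` likewise returns a limit, > 1 mg/kg. Compound 3 `Cc1cc(C)c(NC(=O)N(Cc2ccc(-c3ccccn3)cc2)C2CCCCCC2)c(C)c1` also sits at a limit, > 1 mg/kg; it therefore stands at the limit of > 1 mg/kg in this assay, at which 2 of the 3 values shown sit, with compound 1 alone at the limit of > 0.1 mg/kg in this assay, at which 1 of the 3 values shown sits. The step that the two limits leave unreadable from compound 2 to compound 3 cannot be read, as both ends are limits. Compound 4 `Cc1cc(C)c(NC(=O)N(Cc2ccc(-n3cncn3)cc2)C2CCCCCC2)c(C)c1` differs from compound 3 by 1H-1,2,4-triazol-1-yl in place of pyridin-2-yl on an aromatic carbon. For the measured compounds named here, no measured step concerns this change, so no size or direction is expected from the data; the expected step that the limit leaves unreadable from compound 3 to compound 4 is set near zero. Compound 4 is thus estimated at 2 mg/kg, within 0.5 mg/kg to 10 mg/kg, with a further limit the likeliest outcome.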

Compound 4, dose for half-maximal effect: > 1 mg/kg
Compound 4 gave a limit, no number; the forecaster's own chance of this, stated with the estimate: 70%; the middle value is on the limit's open side.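

Compound 3 and compound 4 both give only limits in this assay; the step of 1H-1,2,4-triazol-1-yl in place of pyridin-2-yl cannot be read. The compounds shown leave open whether this swap changes the dose needed at all.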